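Swapping 4-methoxyphenyl for phenethyl on a sulfur

A few compounds are considered here, and "the series" means these few. Any claim that something is new, unique, unknown or untested is made for them only; others in the source may bear on it.

In a functional assay on A549 cells (Homo sapiens) for inhibition, read by CCK-8 assay, with a stated time of 72 h, tested at 8 uM (on this read-out higher numbers stand for more inhibition of growth at the one concentration tested and lower numbers for less inhibition of growth), compound 1 `COc1ccc(SCc2ccc(C(=O)Nc3ccccc3N)cc2)cc1` gives 70.7% and compound 2 `COc1ccc(SCc2ccc(C(=O)Nc3ccccc3N)cc2)cc1OC` gives 80.1% on the same read-out. Among the compounds with values here, compound 1 has only this one measured neighbour, and the two lie within the scatter of each other. Compound 3 `Nc1ccccc1NC(=O)c1ccc(CSCCc2ccccc2)cc1` keeps the shared core and differs from compound 1 on the sulfur: phenethyl in place of 4-methoxyphenyl on a sulfur is the whole change. Within the data shown here, the only measured step, a number 9.4 percentage points higher from compound 1 to compound 2 (within the scatter) in size, places methoxy in place of hydrogen on an aromatic carbon. Among the measured compounds shown here, it is a weak guide, since no measured compound carries phenethyl. With so little evidence, no step beyond the scatter is expected in this assay here. The estimated step, a number 4.7 percentage points lower from compound 1 to compound 3 (within the scatter) in size, is therefore small and uncertain. Compound 3 is estimated at 66% with an expected range of 45% to 82% in this test.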

Compound 3, percent growth inhibition at one concentration: 84.1%
For compound 3 the middle estimate is 18.1 percentage points below the measured one; measured number above the stated range.
By their numbers in this assay, from the lowest: compounds 1, 2 and 3 (each within the scatter of the next, the first and the last beyond it).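

In this assay, within the data shown here, the change on the sulfur gives a number 13.4 percentage points higher from compound 1 to compound 3 (beyond the scatter) and is the first step here to lie beyond the scatter, so the group on this sulfur can shift growth inhibition at the one concentration tested. The size of the group does not tell the two apart on a simple count: both groups have 8 heavy atoms and one six-membered aromatic ring, yet phenethyl has no oxygen and 4-methoxyphenyl has one. Nothing measured here explains the step.

As far as these compounds go, it remains open whether the two-carbon chain, the loss of the methoxy oxygen or both matter, since the swap changes them together. A benzyl group, a longer chain such as 3-phenylpropyl, or a plain phenyl on the sulfur would help separate these effects.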